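From cyclopropyl to propargyl: a step behind a limit

The source may report more compounds than this note shows. Statements on the series, on what has been measured and on what is new or still open speak of the compounds shown alone.

Compound 1 `C=CCNc1nc(N)nc2c1ncn2[C@H]1C[C@H](N=[N+]=[N-])[C@@H](CO)O1`: > 100000 nM, a limit
Compound 2 `[N-]=[N+]=N[C@H]1C[C@H](n2cnc3c(NCCCCCO)nc(N)nc32)O[C@@H]1CO`: > 100000 nM, a limit
Compound 3 `[N-]=[N+]=N[C@H]1C[C@H](n2cnc3c(NC4CC4)nc(N)nc32)O[C@@H]1CO`: > 100000 nM, a limit

In an ADME assay on Vero cells (Chlorocebus sabaeus) for cytotoxicity, with a stated time of 5 days (a higher number here means a weaker inhibitor, a lower number a stronger inhibitor), compound 3 gives > 100000 nM, which is a limit of the assay and not a number. It has company there, since the whole set sits at one place: the limit of > 100000 nM in this assay, at which 3 of the 3 values shown sit. Compound 3 therefore offers a ceiling of measurement as its starting point, not a value.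

The next compound, compound 4 `C#CCNc1nc(N)nc2c1ncn2[C@H]1C[C@H](N=[N+]=[N-])[C@@H](CO)O1`, has propargyl in place of cyclopropyl on a nitrogen on an aromatic ring.

Among the compounds with values here, three measured steps bear on this change. The closest are a step that the two limits leave unreadable from compound 1 to compound 3 and a step that the two limits leave unreadable from compound 2 to compound 3, both of which alter the group on that same nitrogen. The third is a step that the two limits leave unreadable from compound 1 to compound 2. None of the three has a size that can be read, so they offer no measured shift to carry over and no direction to follow. The groups tried so far have all ended at the same limit in this assay, so no step beyond the scatter is expected here. The expected change is a number no higher from compound 3 to compound 4 (the limit leaves the size open). Compound 4 is estimated at 100000 nM, with an expected range from 50000 nM to 200000 nM.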

Compound 4, half-maximal inhibitory concentration: > 100000 nM
Compound 4 gave a limit, no number; the forecaster's own chance of this, stated with the estimate: 85%; the middle value sits exactly at the limit.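

In this assay, compound 4 gives a limit and not a number, so its steps from compound 1, compound 2 and compound 3 cannot be read. The whole set now sits at one place: the limit of > 100000 nM in this assay, at which 4 of the 4 values shown sit. The compounds shown leave open whether any group on that nitrogen changes the read-out, and at what concentration any of the four would inhibit.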